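The source may hold more compounds than are shown below. What is called first, only, known or untested is meant among the compounds shown, and "the series" means these compounds.

Measured so far in a functional assay on RAW264.7 cells (Mus musculus) for inhibition, read by Griess assay, with stated times of 2 h and 24 h; on this read-out higher numbers stand for weaker inhibition and lower numbers for stronger inhibition:
- compound 1 `CCn1cc(COc2cc(O)c3c(c2)O[C@H](c2ccc(OC)c(O)c2)C/C3=N\O)nn1`: 3140 nM
- compound 2 `CCCCn1cc(COc2cc(O)c3c(c2)O[C@H](c2ccc(OC)c(O)c2)C/C3=N\O)nn1`: 8900 nM

Of these two, compound 2 has the higher number, at 8900 nM. Compound 3 `COc1ccc([C@@H]2C/C(=N\O)c3c(O)cc(OCc4cn(CC5CC5)nn4)cc3O2)cc1O` is still unmeasured. It carries cyclopropyl in place of propyl on a saturated chain carbon bound to an aromatic nitrogen. The same change reads butyl to cyclopropylmethyl.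

Among the measured compounds shown here, one measured step bears on this: a 2.8-fold higher number from compound 1 to compound 2 (0.45 log units; beyond the scatter). It is modest and comes from ethyl in place of hydrogen on a saturated chain carbon. For the measured compounds named here, no compound with a ring at this place has been measured, so the evidence is thin. A small to modest move towards compound 1 is expected in this assay, possibly no more than scatter. The estimated change is a 1.8-fold lower number from compound 2 to compound 3 (0.25 log units; within the scatter). For compound 3 the expected value is 5000 nM, with an estimated range of 2300 nM to 11000 nM.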

Compound 3, half-maximal inhibitory concentration: 6320 nM
For compound 3 the middle estimate is 1.3-fold (0.10 log units) below the measured one, and the stated range covers the measured number.
By their numbers in this assay, from the lowest: compounds 1, 3 and 2 (each within the scatter of the next, the first and the last beyond it).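

In this assay the only ring shown at this place, cyclopropyl in place of propyl on a saturated chain carbon bound to an aromatic nitrogen, gives a 1.4-fold lower number from compound 2 to compound 3 (0.15 log units; within the scatter), so butyl and cyclopropylmethyl cannot be told apart here. Against the ethyl group, the same change gives a 2.0-fold higher number from compound 1 to compound 3 (0.30 log units; within the scatter), which places cyclopropylmethyl within the scatter of both open chains, while those two chains alone stand apart with a 2.8-fold higher number from compound 1 to compound 2 (0.45 log units; beyond the scatter) in this series. Nothing available here accounts for these numbers.

Going by these compounds, whether a benzyl or cyclohexylmethyl group, or a chain ending in an amine or a carboxylic acid, stays in this range remains open. Any trend with chain length rests on ethyl and butyl alone.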